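Urea series: macrophage cytotoxicity and the outlook for compound 4

The compounds below may be only part of what the source reports. "The series", "measured", "known", "first", "only" and "open" are said of these compounds alone.

Three members of the series have been run in an ADME assay on cells (Peritoneal macrophage cell, Mus musculus) for cytotoxicity, read by fluorescence and resazurin assay, with a stated time of 3 days; a lower number here means that less compound is tolerated, a higher number that more compound is tolerated. Compound 1 `O=C(NCc1ccccc1)Nc1[nH]nc(-c2ccccn2)c1Cl` returns only a limit there, > 64000 nM. Compound 3 `COc1ccc(C(=O)Nc2[nH]nc(-c3ccccn3)c2C2CC2)cc1` likewise returns a limit, > 64000 nM. Compound 2 `O=C(Nc1cc(-c2ccccn2)n[nH]1)N1CCC(Oc2ccccn2)CC1` also stands at a limit, > 64000 nM, so no number separates it from the other two. Taken together, (the limit of > 64000 nM in this assay, at which 3 of the 3 values shown sit).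

Compound 4 `O=C(Nc1cc(-c2ccccn2)n[nH]1)N1CCC(c2cccc(Cl)c2)CC1` is not yet measured in this assay. It differs from compound 2 by 3-chlorophenyl in place of (pyridin-2-yl)oxy on a saturated ring carbon. Since every measured value is a limit, no step size can be read from the data. The change is expected to leave the result near the same limit, so the step of an at least 1.0-fold lower number from compound 2 to compound 4 (0.02 log units; that floor lies within the scatter) is estimated as within the scatter. For compound 4 the estimate in this assay is 60000 nM, between 20000 nM and 150000 nM, most likely reported again as a limit.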

Compound 4, half-maximal cytotoxic concentration: > 22000 nM
Compound 4: no number, only a limit (the forecaster's own chance of this, stated with the estimate: 70%); the middle value lies beyond the limit too.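

Compound 2 and compound 4 both return only limits in this assay, and no step can be read between them. The compounds shown leave open what concentration any of them actually tolerates, and whether 3-chlorophenyl or (pyridin-2-yl)oxy is better tolerated.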